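Sulfonyl aryl swap on the shared core, compound 3 to 4

The compounds below may be only part of what the source reports. "The series", "measured", "known", "first", "only" and "open" are said of these compounds alone.

Measured so far:
compound 1 `COc1ccc(S(=O)(=O)c2cnc3ccc(C)cc3c2N2CCC(C)CC2)cc1` gives 62%
compound 2 `COc1ccc(S(=O)(=O)c2cnc3ccc(OC)cc3c2N2CCC(C)CC2)cc1` gives 41%
compound 3 `Cc1ccc(S(=O)(=O)c2cnc3ccc(F)cc3c2N2CCC(C)CC2)cc1C` gives 92%

In an assay on isolated protein for displacement of a labelled ligand from metabotropic glutamate receptor 5 (Homo sapiens), with a stated time of 60 min, tested at 1 uM (on this read-out higher numbers stand for more inhibition at the one concentration tested (going by the name of the read-out) and lower numbers for less inhibition), compound 3 stands highest of the three numbers, beyond the scatter above both others; its nearest neighbour is compound 1, and compound 2 lies furthest off. For the measured compounds named here, the one step that can be read directly, a number 21 percentage points lower from compound 1 to compound 2 (beyond the scatter), concerns a methoxy in place of methyl on an aromatic carbon of the core, not the sulfonyl side.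

Compound 4 `COc1ccc(S(=O)(=O)c2cnc3ccc(F)cc3c2N2CCC(C)CC2)cc1` is still unmeasured. It differs from compound 3 in one place: 4-methoxyphenyl in place of 3,4-dimethylphenyl on a sulfonyl sulfur. Going by the values given here, no measured step swaps one aryl on the sulfonyl sulfur for another, so the direct bearing of the data is thin. Compound 1 and compound 2, which both carry 4-methoxyphenyl there, sit well below compound 3, while the methoxy-for-methyl step on the core cost points. Compound 4 is therefore expected to move by a number 24 percentage points lower from compound 3 to compound 4 (beyond the scatter), downward, likely beyond the scatter. The estimate for compound 4 is 68%, with a range of 48% to 86%.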

Compound 4, a percentage reported as inhibition, at one concentration (the size of the read-out at that concentration, not a potency): 85%
Beside the measured number, compound 4's estimate is 17 percentage points below it; measured number inside the range.
By their numbers in this assay, from the lowest: compound 2; then compound 1; then compounds 4 and 3 (each within the scatter of the next).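

In this assay, for the compounds shown here, the first step at the sulfonyl sulfur, 4-methoxyphenyl in place of 3,4-dimethylphenyl, gives a number 7 percentage points lower from compound 3 to compound 4 (within the scatter) and so does not separate the two aryl groups. Going by these compounds alone, with 4-methoxyphenyl held constant on that sulfur, the change on the aromatic carbon of the core is the one that moves the number: fluoro in place of methoxy gives a number 44 percentage points higher from compound 2 to compound 4 (beyond the scatter) while fluoro in place of methyl gives a number 23 percentage points higher from compound 1 to compound 4 (beyond the scatter) in the same direction. No measured evidence bears on what lies behind these steps.

Going by these compounds, how a chloro or a nitrile on that aromatic carbon would read remains open. So does whether a pyridyl, or a phenyl carrying a carboxylic acid, on the sulfonyl sulfur would keep the number of compound 4 85% in this read-out.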